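Swapping a Trifluoromethyl for a Single Fluorine

A few compounds are considered here, and "the series" means these few. Any claim that something is new, unique, unknown or untested is made for them only; others in the source may bear on it.

Two quinolinone-type analogues have been measured in a functional assay on HL-60 cells (Homo sapiens), read by MTT assay, with a stated time of 72 h; on this read-out higher numbers stand for weaker inhibition of growth and lower numbers for stronger inhibition of growth. Compound 1 `Cc1ccc2c(O)cc(=O)[nH]c2c1` gives 10000000 nM, while compound 2 `O=c1cc(O)c2ccc(C(F)(F)F)cc2[nH]1` gives 900000 nM. Among the measured compounds shown here, the only measured step, an 11-fold lower number from compound 1 to compound 2 (1.05 log units; beyond the scatter), shows that changing the substituent on the aromatic carbon matters a great deal here, and compound 2 stands as the lower of the two numbers. Compound 3 `O=c1cc(O)c2ccc(F)cc2[nH]1` has not yet been measured; it differs from compound 2 by fluoro in place of trifluoromethyl on an aromatic carbon. For the measured compounds named here, no measured step covers exactly this change, so the step from methyl to trifluoromethyl is the only guide. Going by the values given here, since fluoro is neither the group that gave compound 1 its high number nor the one that gave compound 2 its lower value, a moderate rise is expected, estimated as a 3.3-fold higher number from compound 2 to compound 3 (0.52 log units; beyond the scatter). In this assay compound 3 is therefore expected at about 3000000 nM, within a range of 900000 nM to 10000000 nM.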

Compound 3, concentration for 50% growth inhibition: 10000000 nM
Compound 3: the middle estimate sits 3.3-fold (0.52 log units) below what was measured; measured number inside the range.
By their numbers in this assay, from the lowest: compound 2; then compounds 1 and 3 (each within the scatter of the next).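

In this assay, the lower number seen with trifluoromethyl does not carry over to a single fluoro on this aromatic carbon: fluoro in place of trifluoromethyl gives an 11-fold higher number from compound 2 to compound 3 (1.05 log units; beyond the scatter), and fluoro in place of methyl gives no change at the digits printed from compound 1 to compound 3 (within the scatter). Among these three groups, then, only trifluoromethyl stands apart, so the earlier step from methyl cannot be credited to the mere presence of a fluorine atom at this place. Nothing measured here accounts for the gap between these groups, and its cause remains unknown.

Going by these compounds, it remains open where a chlorine atom, an amine, a carboxylic acid or a longer chain on this carbon would fall relative to these compounds. On these data alone, it is also open whether trifluoromethyl would stand apart in the same way at another place on the shared core.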